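Acid to Amide on the Ring: Estimating Compound 4

The compounds below may be only part of what the source reports. "The series", "measured", "known", "first", "only" and "open" are said of these compounds alone.

Compound 1, `Cc1cc(C(=O)N2CCCCc3ccccc32)ccc1CNC(=O)Nc1ccccc1`: 130 nM
Compound 2, `Cc1cc(C(=O)N2CCCCc3ccccc32)ccc1CNC(=O)NCC(=O)N(C)C`: 58 nM
Compound 3, `Cc1cc(C(=O)N2CCCCc3ccccc32)ccc1CNC(=O)N1CCC[C@H]1C(=O)O`: 680 nM

The three measured compounds share one core and differ only in the group joined to the urea carbonyl. In a functional assay on HEK293 cells for agonist activity at Vasopressin V2 receptor (Homo sapiens), read by a luciferase reporter and cAMP accumulation (on this read-out lower numbers stand for an effect already at smaller amounts and higher numbers for an effect only at larger amounts of compound), compound 3 gives the highest number of the three; the steps of a 5.2-fold higher number from compound 1 to compound 3 (0.72 log units; beyond the scatter) and a 12-fold higher number from compound 2 to compound 3 (1.07 log units; beyond the scatter) both run upward and lie beyond the scatter, so compound 3 is the weakest of the measured set. Compound 4, `Cc1cc(C(=O)N2CCCCc3ccccc32)ccc1CNC(=O)N1CC(=O)C[C@H]1C(=O)N(C)C`, is the next member: 2-(dimethylcarbamoyl)-4-oxopyrrolidin-1-yl in place of 2-carboxypyrrolidin-1-yl on a carbonyl carbon. Going by the values given here, two measured steps bear on this change. The step of a 12-fold higher number from compound 2 to compound 3 (1.07 log units; beyond the scatter) shows that the carboxy-bearing ring scores far worse than a side chain carrying a dimethylcarbamoyl group, and the step of a 2.2-fold lower number from compound 1 to compound 2 (0.35 log units; beyond the scatter) also favours that group. Among the compounds with values here, compound 4 restores a dimethylcarbamoyl group, now on the ring, while the added oxo group has no measured counterpart. Compound 4 is therefore expected to show a clearly lower number, a step of a 4.5-fold lower number from compound 3 to compound 4 (0.66 log units; beyond the scatter), with an estimated value of 150 nM and a range from 40 nM to 600 nM.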

Compound 4, half-maximal effective concentration: 27 nM
For compound 4 the middle estimate is 5.6-fold (0.74 log units) above the measured one, and the stated range ends above it.
By their numbers in this assay, from the lowest: compound 4; then compound 2; then compound 1; then compound 3.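

In this assay, the five-membered ring on this carbonyl carbon is not in itself tied to a high number: with 2-(dimethylcarbamoyl)-4-oxopyrrolidin-1-yl in place of 2-carboxypyrrolidin-1-yl, the result is a 25-fold lower number from compound 3 to compound 4 (1.40 log units; beyond the scatter). This ring also gives a lower number than either open group, ((dimethylcarbamoyl)methyl)amino with a 2.1-fold lower number from compound 2 to compound 4 (0.33 log units; beyond the scatter) and anilino with a 4.8-fold lower number from compound 1 to compound 4 (0.68 log units; beyond the scatter), making compound 4 the lowest of the set. No measurement at hand explains these differences.

From the compounds shown here alone, two things change together in the step to compound 4, the carboxy group giving way to dimethylcarbamoyl and the oxo group appearing, so the share of each stays open. A pyrrolidine ring carrying dimethylcarbamoyl without the oxo group, or a 4-oxopyrrolidine ring keeping the carboxylic acid, would be needed to separate them.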